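Swapping a Phenethyl Arm for Methoxyphenyl: Solubility Outlook

The source may report more compounds than this note shows. Statements on the series, on what has been measured and on what is new or still open speak of the compounds shown alone.

Of the compounds shown here, three that share one core have been measured in a physicochemical assay for solubility, with a stated time of 18 h, at pH 7.4; on this read-out higher numbers stand for higher solubility and lower numbers for lower solubility. Compound 1 `COc1ccc(F)cc1CNCCCNc1ccnc2cc(C3CCCCC3)ccc12` gives 4200 nM, compound 2 `c1ccc(CCc2ccc3c(NCCCNCc4ccco4)ccnc3c2)cc1` gives 4200 nM, and compound 3 `COc1ccc(F)cc1CNCCCNc1ccnc2cc(Cc3ccc(F)cc3Cl)ccc12` gives 4200 nM. For the measured compounds named here, the one direct comparison in hand, no change at the digits printed from compound 1 to compound 3 (within the scatter), exchanges one group on the core for another and leaves the read-out unmoved. Compound 2, which carries a phenethyl group, therefore sits level with compounds 1 and 3; its value and theirs are within the scatter of one another, so no order among them can be claimed.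

Compound 4 `COc1ccc(-c2ccc3c(NCCCNCc4ccco4)ccnc3c2)cc1` is the next step from compound 2. The change is 4-methoxyphenyl in place of phenethyl on an aromatic carbon. Going by the values given here, no measured step copies this exact exchange, and the only step available, the move from cyclohexyl to 2-chloro-4-fluorobenzyl between compounds 1 and 3, shows that exchanging one group on the core for a quite different one can leave solubility where it was. With every measured compound resting at the same value, there is no basis for expecting a move beyond the scatter, and compound 4 is expected to show a step of a 1.2-fold lower number from compound 2 to compound 4 (0.08 log units; within the scatter). Compound 4 is estimated at 3500 nM, with a likely range from 1200 nM to 4300 nM.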

Compound 4, solubility: 32000 nM
Beside the measured number, compound 4's estimate is 9.1-fold (0.96 log units) below it, and the stated range ends below it.
By their numbers in this assay, from the lowest: compounds 1, 2 and 3 (each within the scatter of the next); then compound 4.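

In this assay, for the compounds shown here, this exchange gives a 7.6-fold higher number from compound 2 to compound 4 (0.88 log units; beyond the scatter) and is the first step in the set to pass the scatter, so replacing a group on this aromatic carbon can move the read-out, which the earlier swap of cyclohexyl for 2-chloro-4-fluorobenzyl, with no change at the digits printed from compound 1 to compound 3 (within the scatter), gave no sign of. The two groups that trade places both hold 8 heavy atoms and one six-membered aromatic ring of carbon only, yet 4-methoxyphenyl brings an oxygen and a hydrogen-bond acceptor that phenethyl lacks, and the two groups also differ in how that ring is joined to the core. No measurement here explains the step or separates these differences from one another.

Still open, on these data alone, is whether a plain phenyl group, without the methoxy, or a phenyl group carrying an amine or a carboxylic acid in its place, would read like compound 4 or like compound 2. Also open, as far as these compounds go, is whether 4-methoxyphenyl would give a similar step on the core of compound 1, where the furan-bearing chain of compound 2 is replaced by a methoxy- and fluoro-substituted benzyl group.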